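Shift from 4-methoxyphenyl to 3-methoxyphenyl on the anilino nitrogen

The compounds below may be only part of what the source reports. "The series", "measured", "known", "first", "only" and "open" are said of these compounds alone.

Measured so far in a functional assay on WI-38 VA13 cells (Homo sapiens) for cytotoxicity; on this read-out higher numbers stand for an effect only at larger amounts of compound and lower numbers for an effect already at smaller amounts:
compound 1, `CC(=O)Nc1nc2ccc(NC(=O)c3c(Cl)cccc3Cl)cc2s1`, gives 0.6 ug/mL
compound 2, `COc1ccc(Nc2nc3ccc(NC(=O)c4c(Cl)cccc4Cl)cc3s2)cc1`, gives 0.87 ug/mL

Within the data shown here, compound 2 holds the highest of the two numbers, but its only neighbour is compound 1, and the step of a 1.5-fold higher number from compound 1 to compound 2 (0.16 log units; within the scatter) sits within the scatter, so the two values cannot be ordered.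

Compound 3, `COc1cccc(Nc2nc3ccc(NC(=O)c4c(Cl)cccc4Cl)cc3s2)c1`, differs from compound 2 by 3-methoxyphenyl in place of 4-methoxyphenyl on a nitrogen on an aromatic ring. Among the measured compounds shown here, no measured step bears on this change directly: the single step in hand, a 1.5-fold higher number from compound 1 to compound 2 (0.16 log units; within the scatter), concerns the exchange of acetyl for 4-methoxyphenyl on the same nitrogen, not a change within the methoxyphenyl group, and it did not leave the scatter. The series therefore gives no ground to expect a shift beyond the scatter in this assay for compound 3, in either direction; the expected step is a 1.0-fold higher number from compound 2 to compound 3 (0.01 log units; within the scatter). For compound 3 the estimated value in this assay is 0.9 ug/mL, with a range from 0.35 ug/mL to 2.5 ug/mL.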

Compound 3, half-maximal effective concentration: > 7.2 ug/mL
Compound 3 was reported as a limit (the forecaster's own chance of this, stated with the estimate: 5%); at least 8.0-fold (0.90 log units) between middle value and limit.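

In this assay, the exchange of 4-methoxyphenyl for 3-methoxyphenyl on a nitrogen on an aromatic ring, with the same atoms joined differently, gives an at least 8.2-fold higher number from compound 2 to compound 3 (0.91 log units; beyond the scatter), whereas the exchange of acetyl for 4-methoxyphenyl stayed within the scatter. This position therefore responds to how the methoxyphenyl group is arranged, and 3-methoxyphenyl also stands apart from acetyl, with an at least 12-fold higher number from compound 1 to compound 3 (1.07 log units; beyond the scatter). Compound 3 is reported only as a limit: the limit of > 7.2 ug/mL in this assay, at which 1 of the 3 values shown sits.

The compounds shown give no cause for the step and do not fix how far compound 3 lies past its limit. Going by these compounds, it also remains open whether a hydroxyl or a chlorine in place of the methoxy group of the 3-methoxyphenyl would give a similar number.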